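From ethyl to isopropyl in a cytotoxicity series

This account rests on a few compounds, and the source may have more. Where it says the series, first, only, none or still open, it means among the compounds named here.

Measured in a functional assay on MDA-MB-231 cells (Homo sapiens) for cytotoxicity, read by MTT assay, with a stated time of 48 h; on this read-out lower numbers stand for stronger inhibition and higher numbers for weaker inhibition:
- compound 1 `CC(C)n1c(/C=C2/C(=O)Nc3ccc(Br)cc32)nc2ccccc21`: 3260 nM
- compound 2 `CCn1c(/C=C2/C(=O)Nc3ccc(F)cc32)nc2ccccc21`: > 50000 nM (a limit)
- compound 3 `CCn1c(/C=C2/C(=O)Nc3ccccc32)nc2ccccc21`: > 50000 nM (a limit)

Compound 3 has no numerical value in this assay, only the limit > 50000 nM. This is the limit of > 50000 nM in this assay, at which 2 of the 3 values shown sit, so its true position on the scale is not shown.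

The step to compound 4 `CC(C)n1c(/C=C2/C(=O)Nc3ccccc32)nc2ccccc21` is methyl in place of hydrogen on a saturated chain carbon bound to an aromatic nitrogen and a saturated chain carbon: methyl in place of hydrogen turns the ethyl group into isopropyl. For the measured compounds named here, no measured step covers this change. Going by the values given here, the one single-place step available is a step that the two limits leave unreadable from compound 2 to compound 3, so it offers no size to carry over.

The nearest guide is compound 1, which shares the isopropyl group with compound 4 but also carries a bromo group. Compound 1 gives 3260 nM, a true number rather than a limit. On these data alone, that value gives some reason to expect stronger inhibition with isopropyl, but how much of it would survive without the bromo group is unknown, so the expectation is modest and uncertain.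

The expected change is an at least 2.0-fold lower number from compound 3 to compound 4 (0.30 log units; that floor lies within the scatter), towards stronger inhibition. Compound 4 is estimated at 25000 nM, with an expected range of 6000 nM to 50000 nM.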

Compound 4, half-maximal inhibitory concentration: 30400 nM
Compound 4: the middle estimate sits 1.2-fold (0.08 log units) below what was measured, and the stated range covers the measured number.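

In this assay, for the compounds shown here, compound 4 gives the first true number for the isopropyl group without the bromo group, and the change from ethyl to isopropyl reads as an at least 1.6-fold lower number from compound 3 to compound 4 (0.21 log units; that floor lies within the scatter). That size can be read only as a floor because compound 3 has a limit and not a number: the limit of > 50000 nM in this assay, at which 2 of the 4 values shown sit. The bromo group can now be set against this, since with isopropyl held in place its removal reads as a 9.3-fold higher number from compound 1 to compound 4 (0.97 log units; beyond the scatter), a step beyond the scatter, whereas the floor for the isopropyl step alone stays within it.

The compounds shown leave open how far the true gap between ethyl and isopropyl reaches, and the step between compound 2 and compound 3 cannot be read, so the fluoro group has no size of its own on the ethyl compounds. On these data alone, it also remains open whether a longer chain in place of isopropyl would carry the number further down, and whether a chloro group in place of the bromo group would keep the value of compound 1.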